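Free Amino Group in Place of the Large Substituent

The source may report more compounds than this note shows. Statements on the series, on what has been measured and on what is new or still open speak of the compounds shown alone.

In a functional assay on the whole organism (strain albino) for inhibition, with Rattus norvegicus as the target, read by paw edema, with a stated time of 1 h, at a dose of 20 mmol/kg by the intraperitoneal route (on this read-out higher numbers stand for more inhibition at the one dose given (going by the name of the read-out) and lower numbers for less inhibition), compound 2 `N#CC1=C(/N=C/c2ccc([N+](=O)[O-])cc2)N(c2ccccc2)C(=O)N2CCCCC(N3CCCC3)C12` gives 66%, the higher of the two numbers in hand. For the measured compounds named here, its only measured neighbour, compound 1 `N#CC1=C(NCN2CCCC2)N(c2ccccc2)C(=O)N2CCCCC(N3CCCC3)C12`, gives 22.9% in this assay. Going by the values given here, the one measured step bears directly on the present question: a number 43.1 percentage points higher from compound 1 to compound 2 (beyond the scatter), a large rise when a group of 7 heavy atoms with one five-membered non-aromatic ring was exchanged for a group of 11 heavy atoms with one six-membered aromatic ring of carbon only, on a double-bonded ring carbon. Compound 3 `N#CC1=C(N)N(c2ccccc2)C(=O)N2CCCCC(N3CCCC3)C12` now removes that large group altogether: one nitrogen atom in place of a group of 11 heavy atoms (7 carbon, 2 nitrogen, 2 oxygen; one six-membered aromatic ring of carbon only), on a double-bonded ring carbon. Among the compounds with values here, no measured compound carries the bare amino group, so the size of the step is uncertain, but since the large group accounted for the whole rise seen in a number 43.1 percentage points higher from compound 1 to compound 2 (beyond the scatter), its loss is expected to give a downward step of a number 36 percentage points lower from compound 2 to compound 3 (beyond the scatter) beyond the scatter. Compound 3 is therefore estimated at 30%, in a range from 10% to 55%.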

Compound 3, a percentage reported as inhibition, in the whole organism at one dose (the size of the read-out at that dose, not a potency): 77.9%
Beside the measured number, compound 3's estimate is 47.9 percentage points below it; the whole stated range lies below it.
By their numbers in this assay, from the lowest: compound 1; then compound 2; then compound 3.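

In this assay, the large group on this double-bonded ring carbon proves unnecessary for a high read-out: the change to a plain amino group gives a number 11.9 percentage points higher from compound 2 to compound 3 (beyond the scatter). Hydrogen in place of (pyrrolidin-1-yl)methyl on the amine nitrogen gives a number 55 percentage points higher from compound 1 to compound 3 (beyond the scatter), so both substituted compounds stand below the free amine, and the earlier rise with the aromatic ring no longer reads as a gain over the unsubstituted position. Nothing available explains why the smallest group here gives the highest number.

Still open, going by these compounds, is whether a small group on this nitrogen, such as methyl or acetyl, would keep the number near that of compound 3 or lower it towards that of compound 1. Each compound also has a reading at one dose only, so the ranking says nothing about potency.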